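This account rests on a few compounds, and the source may have more. Where it says the series, first, only, none or still open, it means among the compounds named here.

Compound 1 `COc1ccc(CNc2nc([Se]C)nc3ccccc23)cc1`: in an ADME assay on 184B5 cells (Homo sapiens) for cytotoxicity, read by MTT assay, with a stated time of 72 h (on this read-out lower numbers stand for stronger inhibition of growth and higher numbers for weaker inhibition of growth), compound 1 reaches only the assay limit, > 100000 nM.
Compound 2 `CSc1nc(NCc2ccc([Se]C)cc2)c2ccccc2n1`: in this assay compound 2 likewise gives only a limit, > 100000 nM.
Compound 3 `CSc1nc(NCc2ccccc2)c2ccccc2n1`: in this assay compound 3 also gives only a limit, > 100000 nM.

Compound 3 thus stands at the limit, alongside every other value shown (the limit of > 100000 nM in this assay, at which 3 of the 3 values shown sit). For the measured compounds named here, the only measured step, a step that the two limits leave unreadable from compound 2 to compound 3, cannot be sized because a step that the two limits leave unreadable from compound 2 to compound 3 runs between two limits. The unmeasured compound 4 `COc1ccc(CNc2nc(SC)nc3ccccc23)cc1` differs from compound 3 by methoxy in place of hydrogen on an aromatic carbon. Compound 1 carries that same methoxy group and also sits at the limit, so no step beyond the scatter is expected. Compound 4 is therefore expected at 100000 nM, within 50000 nM to 200000 nM. The expected step is a number no higher from compound 3 to compound 4 (the limit leaves the size open).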

Compound 4, concentration for total growth inhibition: > 100000 nM
Compound 4: a limit, no number; the forecaster's own chance of this, stated with the estimate: 85%; the middle value lies on the limit itself.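

The steps from compound 1, compound 2 and compound 3 to compound 4 cannot be read, since each compound gives only a limit: the limit of > 100000 nM in this assay, at which 4 of the 4 values shown sit. From the compounds shown here alone, whether methoxy, or selenium in place of sulfur, changes growth inhibition in this assay stays open.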